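Difluorophenyl Variant of a Pyridine Amide: Expected Cytotoxicity

This account rests on a few compounds, and the source may have more. Where it says the series, first, only, none or still open, it means among the compounds named here.

Compound 1, `COc1ccc(-c2ccc(C(=O)Nc3ccc(Oc4ccnc5[nH]ccc45)cc3)nc2)cc1`: in a functional assay on PC-3 cells (Homo sapiens) for cytotoxicity, read by MTT assay, with a stated time of 72 h (a lower number here means a stronger inhibitor, a higher number a weaker inhibitor), compound 1 gives > 10000 nM, a limit of the assay rather than a number.
Compound 2, `O=C(Nc1ccc(Oc2ccnc3[nH]ccc23)cc1)c1cc(-c2ccccc2)ccn1`: in this assay compound 2 gives 3270 nM.
Compound 3, `O=C(Nc1ccc(Oc2ccnc3[nH]ccc23)c(F)c1)c1cc(-c2ccccc2)ccn1`: in this assay compound 3 gives > 10000 nM, again a limit.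

Compound 3 thus stands at the limit of > 10000 nM in this assay, at which 2 of the 3 values shown sit. Within the data shown here, the one measured step, an at least 3.0-fold higher number from compound 2 to compound 3 (0.48 log units; beyond the scatter), weakened activity. Compound 4, `O=C(Nc1ccc(Oc2ccnc3[nH]ccc23)c(F)c1)c1cc(-c2ccc(F)cc2F)ccn1`, differs from compound 3 by 2,4-difluorophenyl in place of phenyl on an aromatic carbon. Among the measured compounds shown here, no measured step touches this phenyl group, so its direction is unknown, and with compound 3 already at the limit little change is expected to be seen. Compound 4 is expected to give 15000 nM, within 4000 nM to 60000 nM. This corresponds to an expected step that the limit leaves unreadable from compound 3 to compound 4.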

Compound 4, half-maximal inhibitory concentration: > 10000 nM
Compound 4: only a limit was reported (the forecaster's own chance of this, stated with the estimate: 70%); the middle value does not contradict the limit.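

The step from compound 3 to compound 4 cannot be read, since both report only a limit: the limit of > 10000 nM in this assay, at which 3 of the 4 values shown sit.
The compounds shown leave open whether 2,4-difluorophenyl in place of phenyl changes activity at all, in either direction.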